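Aryl change on the ring nitrogen: expectation for compound 4

This account rests on a few compounds, and the source may have more. Where it says the series, first, only, none or still open, it means among the compounds named here.

Three compounds of the shared core differ only in the aryl group on the aromatic nitrogen. In a functional assay on PC-12 cells (Rattus norvegicus) for cytotoxicity, read by MTT assay, with stated times of 2 h and 24 h, tested at 5 uM (a higher number here means a stronger effect of the compound at the concentration tested, a lower number a weaker effect), compound 1 `CCc1ccc(-n2nc(-c3ccc(C(F)(F)F)cc3O)nc2-c2ccccc2O)cc1` gives 95.4%, compound 2 `COc1ccc(-n2nc(-c3ccc(C(F)(F)F)cc3O)nc2-c2ccccc2O)cc1` gives 86.6% and compound 3 `Oc1cc(C(F)(F)F)ccc1-c1nc(-c2ccccc2O)n(-c2cccc(F)c2)n1` gives 87.7%. Compound 3 stands with both others: a number 7.7 percentage points lower from compound 1 to compound 3 (within the scatter) and a number 1.1 percentage points higher from compound 2 to compound 3 (within the scatter). Compound 4 `Cc1cc(C)cc(-n2nc(-c3ccc(C(F)(F)F)cc3O)nc2-c2ccccc2O)c1` differs from compound 3 thus: 3,5-dimethylphenyl in place of 3-fluorophenyl on an aromatic nitrogen. The steps that bear on this are the two just named together with a number 8.8 percentage points lower from compound 1 to compound 2 (within the scatter), all within the scatter, so no aryl change on this nitrogen has moved this assay beyond its scatter among these compounds. For compound 4 no step beyond the scatter is therefore expected, a number 1.3 percentage points higher from compound 3 to compound 4 (within the scatter). Compound 4 is estimated at 89%, within 78% to 98%.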

Compound 4, a percentage reported as activity, at one concentration (the size of the read-out at that concentration, not a potency): 102%
The estimate for compound 4 lay 13 percentage points below the measured number, and the stated range ends below it.
By their numbers in this assay, from the lowest: compounds 2, 3, 1 and 4 (each within the scatter of the next, the first and the last beyond it).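

In this assay the aryl group on this nitrogen now gives steps beyond the scatter, though modest ones: a number 14.3 percentage points higher from compound 3 to compound 4 (beyond the scatter) and a number 15.4 percentage points higher from compound 2 to compound 4 (beyond the scatter). The 3,5-dimethylphenyl group thus separates from 3-fluorophenyl and 4-methoxyphenyl, but not from 4-ethylphenyl, as a number 6.6 percentage points higher from compound 1 to compound 4 (within the scatter) shows. Nothing available explains this difference. Open, on these data alone, is whether one methyl group, as in 3-methylphenyl, would give the same read-out. Also open, as far as these compounds go, is how an amine or a carboxylic acid on this aryl group would read.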